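The compounds below may be only part of what the source reports. "The series", "measured", "known", "first", "only" and "open" are said of these compounds alone.

Working notes on the series: in an ADME assay on microsomes from liver (Rattus norvegicus) for metabolic stability (on this read-out higher numbers stand for fast clearance and lower numbers for slow clearance), compound 1 (`Cc1cc(=O)[nH]c(-c2cc(Oc3ccc(S(C)(=O)=O)cc3)cc(OC(C)C)c2)n1`) gives 96 mL/min/kg and compound 2 (`CCC(CC)Oc1cc(Oc2cnc(C(=O)N(C)C)nc2)cc(-c2nccc(=O)[nH]2)c1`) gives 91 mL/min/kg. Among the measured compounds shown here, these two numbers lie within the scatter of each other, so compound 2 stands level with the only other measured compound. For the measured compounds named here, the two compounds differ in more than one place, and no measured pair isolates a single change. Compound 3 (`C[C@@H](CO)Oc1cc(Oc2cnc(C(=O)N(C)C)nc2)cc(-c2nccc(=O)[nH]2)c1`) departs from compound 2 in one place: 1-(hydroxymethyl)ethyl in place of pentan-3-yl on an oxygen on an aromatic ring, with 1-(hydroxymethyl)ethyl in place of pentan-3-yl on an oxygen on an aromatic ring. Going by the values given here, the data hold no measured step for this change in this assay, so the expectation rests on the structural change alone. A move toward slower clearance, modestly beyond the scatter, is expected starting from compound 2, which gives 91 mL/min/kg. The estimated step is a 2.3-fold lower number from compound 2 to compound 3 (0.36 log units; beyond the scatter). For compound 3 the estimated clearance is 40 mL/min/kg, with an expected range of 18 mL/min/kg to 80 mL/min/kg.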

Compound 3, clearance: 26 mL/min/kg
Compound 3: the middle estimate sits 1.5-fold (0.19 log units) above what was measured; the measured number falls inside the stated range.
By their numbers in this assay, from the lowest: compound 3; then compounds 2 and 1 (each within the scatter of the next).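

In this assay the group on an oxygen on an aromatic ring proves able to move clearance: the series now has its first single-place change, and it reads as a 3.5-fold lower number from compound 2 to compound 3 (0.54 log units; beyond the scatter) in favour of 1-(hydroxymethyl)ethyl over pentan-3-yl. The entering group differs from the leaving one in its carbon count, its hydrogen-bond donor and acceptor, and its defined stereocentre, and this single step cannot separate these differences. Nothing in the data on hand accounts for the step.

The compounds shown leave open whether the hydroxyl of 1-(hydroxymethyl)ethyl is needed for this step, or whether a simple ethyl or methoxyethyl group on the same oxygen would give a similar number. Also open, on these data alone, are the other stereoisomer of 1-(hydroxymethyl)ethyl and the effect of a longer hydroxyalkyl chain, an amine or a carboxylic acid at this place.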